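A few compounds are considered here, and "the series" means these few. Any claim that something is new, unique, unknown or untested is made for them only; others in the source may bear on it.

Measured so far:

Compound 1, `CC(C)(C)OC(=O)N1C(=O)CC[C@H]1C(=O)N1CCC(NS(=O)(=O)c2cc(S(=O)(=O)c3ccccc3)ccc2C(F)(F)F)CC1`: 130 nM
Compound 2, `CC(C)(C)CC(=O)N1CCC[C@H]1C(=O)N1CCC(NS(=O)(=O)c2cc(S(=O)(=O)c3ccccc3)ccc2C(F)(F)F)CC1`: 20 nM

Both compounds were tested in an assay on isolated protein for binding affinity to secreted frizzled-related protein 1 (Homo sapiens), read by fluorescence; a lower number here means a stronger inhibitor, a higher number a weaker inhibitor. Compound 2 gives the lowest of the two numbers with 20 nM, and compound 1 sits higher at 130 nM, a gap that lies beyond the usual scatter of repeated measurements. Compound 3, `CC(C)(C)CCN1CCC[C@H]1C(=O)N1CCC(NS(=O)(=O)c2cc(S(=O)(=O)c3ccccc3)ccc2C(F)(F)F)CC1`, is not yet measured. It differs from compound 2 in one place: 3,3-dimethylbutyl in place of neopentylcarbonyl on an amine nitrogen in a ring. Among the measured compounds shown here, no pair of measured compounds shows this kind of change, so there is nothing here that tells how removing the carbonyl of the amide shifts the number. A moderate step upward, toward a weaker binder, is expected, a 3.0-fold higher number from compound 2 to compound 3 (0.48 log units; beyond the scatter), but with wide uncertainty in both directions. For compound 3 in this assay the expected value is 60 nM, within a range from 15 nM to 300 nM.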

Compound 3, half-maximal inhibitory concentration: 30 nM
Beside the measured number, compound 3's estimate is 2.0-fold (0.30 log units) above it; measured number inside the range.
By their numbers in this assay, from the lowest: compounds 2 and 3 (each within the scatter of the next); then compound 1.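

In this assay, among the compounds shown here, putting 3,3-dimethylbutyl in place of neopentylcarbonyl on the amine nitrogen in the ring gives a 1.5-fold higher number from compound 2 to compound 3 (0.18 log units; within the scatter), the first reading of any single change at this position. The two numbers cannot be told apart, so in this assay the carbonyl of the amide can be replaced by a plain carbon chain with no measurable cost in binding. Nothing shown explains why these two compounds read alike.

Going by these compounds, whether this position accepts groups of other kinds remains open, since both groups compared here end in the same bulky carbon branch. A shorter chain, a chain ending in an amine or a carboxylic acid, or a bare ring nitrogen carrying only hydrogen could each show how much the group on this nitrogen matters.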